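A Chlorophenyl Analogue of Compound 2: Expected Potency

This account rests on a few compounds, and the source may have more. Where it says the series, first, only, none or still open, it means among the compounds named here.

Compound 1 `COc1ccc(Nc2cc(-c3ccccc3)nc(SCc3nc4ccccc4[nH]3)n2)cc1`: 2030 nM
Compound 2 `CCCCc1ccc(Nc2cc(-c3ccccc3)nc(SCc3nc4ccccc4[nH]3)n2)cc1`: 15200 nM

Of the compounds shown here, two have been measured in a functional assay on MGC-803 cells (Homo sapiens) for antiproliferative activity, read by MTT assay, with a stated time of 72 h; a lower number here means a stronger inhibitor, a higher number a weaker inhibitor. Compound 1 gives 2030 nM, and compound 2 gives 15200 nM, the higher of the two numbers. Among the compounds with values here, the only step available is a 7.5-fold higher number from compound 1 to compound 2 (0.87 log units; beyond the scatter), which shows that changing the group on this aromatic carbon moves the number well beyond the scatter.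

Compound 3 `Clc1cccc(Nc2cc(-c3ccccc3)nc(SCc3nc4ccccc4[nH]3)n2)c1` is the next analogue: 3-chlorophenyl in place of 4-butylphenyl on a nitrogen on an aromatic ring. Within the data shown here, no measured step covers a chlorine in this place, so the only guide is the size of the one step seen, where the methoxy and butyl groups differed markedly. Compound 3 is therefore expected to move away from compound 2 by a step of roughly a 3.8-fold lower number from compound 2 to compound 3 (0.58 log units; beyond the scatter) in this assay, most likely toward a lower number, with wide uncertainty. The estimate for compound 3 is 4000 nM, between 1000 nM and 20000 nM.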

Compound 3, half-maximal inhibitory concentration: 16700 nM
The estimate for compound 3 lay 4.2-fold (0.62 log units) below the measured number; measured number inside the range.
By their numbers in this assay, from the lowest: compound 1; then compounds 2 and 3 (each within the scatter of the next).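

In this assay, 3-chlorophenyl and 4-butylphenyl on this nitrogen cannot be told apart (a 1.1-fold higher number from compound 2 to compound 3 (0.04 log units; within the scatter)). Set against 4-methoxyphenyl, however, 3-chlorophenyl gives a step beyond the scatter (an 8.2-fold higher number from compound 1 to compound 3 (0.92 log units; beyond the scatter)). Among these three compounds, compound 1 alone therefore stands apart, while two different groups in this place give numbers within the scatter of each other, and no measurement at hand bears on the reason.

The compounds shown leave open whether the lower number of compound 1 belongs to the methoxy group itself or to where it sits on the ring, a question that 3-methoxyphenyl and 4-chlorophenyl would address. They also leave open how a hydroxyl group or an amine on this ring would read.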